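The source may hold more compounds than are shown below. What is called first, only, known or untested is meant among the compounds shown, and "the series" means these compounds.

Of the compounds shown here, three of closely related structure have been tested in a functional assay on DU-145 cells (Homo sapiens) for inhibition, read by sulforhodamine B assay, with a stated time of 48 h (a higher number here means a weaker inhibitor, a lower number a stronger inhibitor), and a fourth awaits its number. Compound 1, `CO[C@@H]1CC=C2NN(c3cc(Cl)cc(Cl)c3)C(=O)C[C@]2(C)O1`, gives 21300 nM. Compound 2, `CO[C@@H]1CC=C2NN(c3cc(Cl)cc(Cl)c3)C(=O)C[C@]2(c2ccncc2)O1`, differs from it by a single replacement, (pyridin-4-yl in place of methyl on a saturated ring carbon), and in this assay compound 2 gives 7600 nM. That replacement brought a 2.8-fold lower number from compound 1 to compound 2 (0.45 log units; beyond the scatter).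

Compound 3, `COc1cc(OC)cc(N2NC3=CC[C@@H](OC)O[C@@]3(C)CC2=O)c1`, carries a different core, and the difference between the two cores is not broken down here. In this assay compound 3 gives 22200 nM, a number that sits within the scatter of the value of compound 1, so the two cannot be ranked against each other.

Compound 4, `COc1cc(OC)cc(N2NC3=CC[C@@H](OC)O[C@@]3(c3ccncc3)CC2=O)c1`, is compound 3 with the same replacement that turned compound 1 into compound 2: pyridin-4-yl in place of methyl on a saturated ring carbon. The place described for this change is not worded quite the same as for the earlier one, which sat on a saturated ring carbon of a six-membered non-aromatic ring with 1 oxygen, next to the ring oxygen, next to the ring atom that bears a fused ring, two ring bonds from the ring atom that bears a methoxy group; here the carbon is described as belonging to a six-membered non-aromatic ring with 2 nitrogen. It is therefore the same kind of change, not the same change. Given the starting point of compound 3 at 22200 nM, the step is expected to be about a 2.8-fold lower number from compound 3 to compound 4 (0.44 log units; beyond the scatter), because the earlier step was a 2.8-fold lower number from compound 1 to compound 2 (0.45 log units; beyond the scatter). Compound 4 is thus expected to give roughly 8000 nM, most likely somewhere between 3500 nM and 18000 nM.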

Compound 4, half-maximal inhibitory concentration: 5900 nM
Estimate against measurement, compound 4: 1.4-fold (0.13 log units) above; the range from low to high includes it.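

On the second core, pyridin-4-yl in place of methyl on a saturated ring carbon brought a 3.8-fold lower number from compound 3 to compound 4 (0.58 log units; beyond the scatter) in this assay, so the number fell here as it did on the first core. Set side by side, the two steps are too close to tell apart, and the change can be read as carrying over between these two cores with about the same size: the same change on two cores in this assay, a 2.8-fold lower number (0.45 log units; beyond the scatter) from compound 1 to compound 2 and a 3.8-fold lower number (0.58 log units; beyond the scatter) from compound 3 to compound 4, 1.3-fold (0.13 log units) apart, within the scatter of two such steps. Going by these compounds alone, this rests on only two pairs of compounds in a single assay, so it does not show that the same step would appear on a third core or in another assay, and it does not explain why the number falls.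

The compounds shown leave open whether the gain needs pyridin-4-yl itself, since only that group and methyl appear on this carbon, and a plain phenyl ring, a pyridin-3-yl group or a longer chain such as butyl would each test a different part of that question. They also leave open whether an amine or a hydroxyl group in place of the methoxy group on the shared ring would alter the number, or the size of this step.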